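This account rests on a few compounds, and the source may have more. Where it says the series, first, only, none or still open, it means among the compounds named here.

Measured in a functional assay on MT4 cells (Homo sapiens) for cytotoxicity; a lower number here means that less compound is tolerated, a higher number that more compound is tolerated:
- compound 1 `Cc1cn([C@@H]2O[C@H](CO[Si](C)(C)C(C)(C)C)[C@@]3(OS(=O)(=O)C(Br)=C3N)[C@H]2O[Si](C)(C)C(C)(C)C)c(=O)[nH]c1=O`: 18000 nM
- compound 2 `C=CCNC1=CS(=O)(=O)O[C@@]12[C@@H](CO[Si](C)(C)C(C)(C)C)O[C@@H](n1cc(C)c(=O)n(C)c1=O)[C@@H]2O[Si](C)(C)C(C)(C)C`: 25000 nM

For the measured compounds named here, compound 1 and compound 2 lie within the scatter of each other, so compound 1 does not stand apart from the only other measured member of the series. Compound 3 `Cc1cn([C@@H]2O[C@H](CO[Si](C)(C)C(C)(C)C)[C@@]3(OS(=O)(=O)C(Cl)=C3N)[C@H]2O[Si](C)(C)C(C)(C)C)c(=O)[nH]c1=O` has chloro in place of bromo on a double-bonded ring carbon. Going by the values given here, no measured pair shows this exchange, so no step beyond the scatter is expected in this assay. The estimated change is a 1.1-fold higher number from compound 1 to compound 3 (0.05 log units; within the scatter). Compound 3 is estimated at 20000 nM, with an expected range of 9000 nM to 45000 nM.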

Compound 3, half-maximal cytotoxic concentration: 5400 nM
Estimate against measurement, compound 3: 3.7-fold (0.57 log units) above, outside the stated range (below it).
By their numbers in this assay, from the lowest: compound 3; then compounds 1 and 2 (each within the scatter of the next).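

In this assay, the halogen on the double-bonded ring carbon next to the ring sulfur is not a silent place in the series, as chloro in place of bromo gives the first readable step (a 3.3-fold lower number from compound 1 to compound 3 (0.52 log units; beyond the scatter)). That step is beyond the scatter but rests on a single pair. Nothing measured on these compounds accounts for it.

Open, from the compounds shown here alone, is whether the number tracks the halogen or any replacement of bromo, which fluoro, hydrogen or methyl at this carbon could test. Also open, going by these compounds, is whether the step persists with free hydroxyl groups in place of the silyl ethers.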